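This account rests on a few compounds, and the source may have more. Where it says the series, first, only, none or still open, it means among the compounds named here.

Measured compounds:
compound 1, `CC(C)=CCC1Cc2c(OC(=O)Nc3ccc(F)cc3)cc(=O)n(CCCO)c2CC1(C)C`, 71.2%
compound 2, `CC(C)=CCC1Cc2c(OC(=O)Nc3ccc(Cl)cc3)cc(=O)n(CCCO)c2CC1(C)C`, 49.8%
compound 3, `CC(C)=CCC/C(C)=C/CC1Cc2c(OC(=O)Nc3ccc(F)c(F)c3)cc(=O)n(CCCO)c2CC1(C)C`, 43.7%

All three were tested in a functional assay on PANC-1 cells (Homo sapiens) for inhibition, read by MTT assay, with a stated time of 24 h, tested at 10 uM; on this read-out lower numbers stand for less inhibition and higher numbers for more inhibition at the one concentration tested (going by the name of the read-out). Compound 1 and compound 2 share a core and differ only by chloro in place of fluoro on an aromatic carbon; that change gave a number 21.4 percentage points lower from compound 1 to compound 2 (beyond the scatter). Compound 3 has a different core, and the difference between the two cores is not broken down here. Compound 4, `CC(C)=CCC/C(C)=C/CC1Cc2c(OC(=O)Nc3ccc(F)c(Cl)c3)cc(=O)n(CCCO)c2CC1(C)C`, is not yet measured; it differs from compound 3 by chloro in place of fluoro on an aromatic carbon. This is the same kind of change as from compound 1 to compound 2, but the place differs: in compound 2 the chloro sits para to a large group, while in compound 4 it sits ortho to a fluoro group and meta to a large group. Going by the earlier step, a downward step is expected for compound 4, a number 11.7 percentage points lower from compound 3 to compound 4 (beyond the scatter), though perhaps smaller because the surroundings differ from those behind a number 21.4 percentage points lower from compound 1 to compound 2 (beyond the scatter). Compound 4 is therefore estimated at 32%, between 17% and 50%.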

Compound 4, a percentage reported as inhibition, at one concentration (the size of the read-out at that concentration, not a potency): 25%
For compound 4 the middle estimate is 7 percentage points above the measured one; low and high end bracket the measured number.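

In this assay, chloro in place of fluoro gave a number 18.7 percentage points lower from compound 3 to compound 4 (beyond the scatter), so the number also fell on this second core. The two steps agree closely: the same change on two cores in this assay, a number 21.4 percentage points lower (beyond the scatter) from compound 1 to compound 2 and a number 18.7 percentage points lower (beyond the scatter) from compound 3 to compound 4, 2.7 percentage points apart, within the scatter of two such steps. This shows that the change carried over between these two cores, in direction and in size, at the one concentration tested, but it does not show why the number falls or that it would fall the same way on any other core.

As far as these compounds go, it remains open whether a bromo or a methyl on the same aromatic carbon would give a step of similar size. Also open, from the compounds shown here alone, is how either core would respond to an amine in place of the hydroxyl at the end of the chain.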